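Replacing the Phenyl of Compound 3 with a Methyl

The source may hold more compounds than are shown below. What is called first, only, known or untested is meant among the compounds shown, and "the series" means these compounds.

Of the compounds shown here, three sharing one core have been tested in a functional assay on MCF7 cells (Homo sapiens) for antiproliferative activity, read by MTT assay, with a stated time of 24 h, tested at 12.5 uM; on this read-out higher numbers stand for a weaker effect at the one concentration tested and lower numbers for a stronger effect. Compound 1 `OC(CCn1nc2c(Br)c(Br)c(Br)c(Br)c2n1)c1cccc(Cl)c1` gives 97%. Compound 2 `C[C@@H](O)CCn1nc2c(Br)c(Br)c(Br)c(Br)c2n1` gives 109%. Compound 3 `OC(CCn1nc2c(Br)c(Br)c(Br)c(Br)c2n1)c1ccccc1` gives 115%, which is the highest of the three numbers, though its gap to compound 2 lies within the usual scatter, while the step of a number 18 percentage points higher from compound 1 to compound 3 (beyond the scatter) is beyond it.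

Compound 4 `CC(O)CCn1nc2c(Br)c(Br)c(Br)c(Br)c2n1` has not been measured. Its difference from compound 3 is methyl in place of phenyl on a saturated chain carbon bound to an oxygen on a saturated carbon and a saturated chain carbon. For the measured compounds named here, no measured step covers exactly this change; the only step on record, hydrogen in place of chloro on an aromatic carbon, is of another kind and says little here. What does bear on it is the pair of compound 2 and compound 3, whose values sit close together, and compound 2 carries the same methyl group that enters in compound 4.

Compound 4 is therefore expected to give a number near that of compound 2, which is 109%, so the expected step of a number 6 percentage points lower from compound 3 to compound 4 (within the scatter) stays within the scatter. The estimate for compound 4 in this assay is 109%, with a range from 95% to 123%.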

Compound 4, a percentage reported as activity, at one concentration (the size of the read-out at that concentration, not a potency): 99%
Beside the measured number, compound 4's estimate is 10 percentage points above it; low and high end bracket the measured number.
By their numbers in this assay, from the lowest: compounds 1, 4, 2 and 3 (each within the scatter of the next, the first and the last beyond it).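

In this assay, methyl in place of phenyl on this saturated chain carbon gives a number 16 percentage points lower from compound 3 to compound 4 (beyond the scatter), so at this position the aromatic ring is not needed for the stronger effect, and the smaller group gives a modest gain over the plain phenyl. Methyl in place of 3-chlorophenyl gives a number 2 percentage points higher from compound 1 to compound 4 (within the scatter), which means that the small alkyl group and the chlorinated ring cannot be told apart here, although phenyl itself stands apart from both. The step of a number 10 percentage points lower from compound 2 to compound 4 (within the scatter) adds a comparison of a different kind, as no atom or bond changes and the only thing that separates the pair is this: the fact that one of compounds 2 and 4 is drawn with a defined configuration and the other without, at the place where they differ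

The compounds shown leave open how the effect changes with a group of intermediate size at this carbon, such as ethyl or a longer chain, or with an amine or a carboxylic acid there. They also leave open whether the S form of the methyl compound would match the R form, and all of these readings come from a single concentration, which gives no potency.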